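Swapping chloro for fluoro on the amide aryl ring

This account rests on a few compounds, and the source may have more. Where it says the series, first, only, none or still open, it means among the compounds named here.

Compound 1, `COc1ccc(C(=O)Nc2cccc(-c3ccnc4c(NC(C)=O)cccc34)c2)cc1OC`, in a functional assay on A375P cells (Homo sapiens) for antiproliferative activity, read by MTT assay, with a stated time of 48 h (a lower number here means a stronger inhibitor, a higher number a weaker inhibitor), gives 5300 nM.
Compound 2, `CC(=O)Nc1cccc2c(-c3cccc(NC(=O)c4ccc(C)c(C)c4)c3)ccnc12`, in this assay gives > 20000 nM, a limit of the assay.
Compound 3, `CC(=O)Nc1cccc2c(-c3cccc(NC(=O)c4ccc(Cl)c(C(F)(F)F)c4)c3)ccnc12`, in this assay gives 2400 nM.

Compound 3 holds the lowest of the two numbers shown; its nearest neighbour is compound 1, with a 2.2-fold lower number from compound 1 to compound 3 (0.34 log units; beyond the scatter). The value of compound 2 sits at the limit of > 20000 nM in this assay, at which 1 of the 3 values shown sits, so an at least 8.3-fold lower number from compound 2 to compound 3 (0.92 log units; beyond the scatter) and an at least 3.7-fold higher number from compound 1 to compound 2 (0.57 log units; beyond the scatter) are known only as bounds. All three measured steps change the aryl group on the carbonyl carbon, and each of them moved the number beyond the scatter.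

Compound 4, `CC(=O)Nc1cccc2c(-c3cccc(NC(=O)c4ccc(F)c(C(F)(F)F)c4)c3)ccnc12`, differs from compound 3 by fluoro in place of chloro on an aromatic carbon. Among the compounds with values here, no measured step swaps one halogen for another on that ring, so the three steps show only that this ring matters; the change here is the smallest of them. Compound 4 is therefore expected to give about 4000 nM, with a likely range from 1500 nM to 12000 nM. The expected step is a 1.7-fold higher number from compound 3 to compound 4 (0.22 log units; within the scatter).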

Compound 4, half-maximal inhibitory concentration: 6800 nM
Compound 4: the middle estimate sits 1.7-fold (0.23 log units) below what was measured; the range from low to high includes it.
By their numbers in this assay, from the lowest: compound 3; then compounds 1 and 4 (each within the scatter of the next). At a limit, above all of these: compound 2.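

Fluoro in place of chloro, on the carbon ortho to a trifluoromethyl group and para to a large group, gives a 2.8-fold higher number from compound 3 to compound 4 (0.45 log units; beyond the scatter), showing that a swap of one halogen for another at this position alone moves the number beyond the scatter. With fluoro in place, the advantage seen for the chloro compound is lost, and the 4-fluoro-3-(trifluoromethyl)phenyl and 3,4-dimethoxyphenyl groups cannot be told apart, with a 1.3-fold higher number from compound 1 to compound 4 (0.11 log units; within the scatter). Compound 2 gives only a limit, so an at least 2.9-fold lower number from compound 2 to compound 4 (0.46 log units; beyond the scatter) stands as a bound: the limit of > 20000 nM in this assay, at which 1 of the 4 values shown sits.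

The compounds shown leave open whether bromo or a plain hydrogen on this carbon would track with chloro or with fluoro. They also leave open whether a nitrile in place of the trifluoromethyl group would alter the effect of this swap.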